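The source may hold more compounds than are shown below. What is called first, only, known or untested is meant among the compounds shown, and "the series" means these compounds.

Measured so far:
- compound 1 `CC=C(c1cc(OC)cc(OC)c1)c1ccc(OC)c(OC)c1`: 480 nM
- compound 2 `CC=C(c1cc(OC)cc(OC)c1)c1ccc(OC)c(O)c1`: 30 nM
- compound 3 `CCOc1cc(C(=CC#N)c2ccc(OC)c(N)c2)ccc1OC`: 19 nM

In a functional assay on HCT-116 cells (Homo sapiens) for cytotoxicity, read by scintillation counting and thymidine incorporation, with a stated time of 72 h (a lower number here means a stronger inhibitor, a higher number a weaker inhibitor), compound 1 gives the highest of the three numbers. Its nearest neighbour in value is compound 2, reached by one change with a 16-fold lower number from compound 1 to compound 2 (1.20 log units; beyond the scatter); compound 3 lies furthest, and the two values of compound 1 and compound 3 simply show a wide gap, compound 3 differing from compound 1 in more than one place.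

Compound 4 `COc1cc(OC)cc(C(=CC#N)c2ccc(OC)c(OC)c2)c1` is the next one to be measured in this assay. It differs from compound 1 as follows: cyano in place of methyl on a double-bonded chain carbon bound to a double-bonded chain carbon. Among the compounds with values here, none of the measured steps covers this change on its own. Within the data shown here, the one step measured, from compound 1 to compound 2, concerns an oxygen substituent on an aromatic ring and was large, but it gives no direct reading on the chain position. Compound 3 does carry a cyano on the double-bonded chain carbon and shows a low number, yet its other differences from compound 1 prevent attributing that value to the cyano alone.

The expectation for compound 4 in this assay is therefore a moderate step, a 3.2-fold lower number from compound 1 to compound 4 (0.51 log units; beyond the scatter), most likely downward, with wide uncertainty. Compound 4 is estimated at 150 nM, within a range from 40 nM to 600 nM.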

Compound 4, half-maximal inhibitory concentration: 18 nM
Estimate against measurement, compound 4: 8.3-fold (0.92 log units) above; measured number outside the range, below it.
By their numbers in this assay, from the lowest: compounds 4, 3 and 2 (each within the scatter of the next); then compound 1.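

In this assay the double-bonded chain carbon bound to a double-bonded chain carbon proves a sensitive position: cyano in place of methyl, with the rest of the core of compound 1 unchanged, gives a 27-fold lower number from compound 1 to compound 4 (1.43 log units; beyond the scatter). Within the data shown here, the low number of compound 3 could not be traced to the cyano, whereas this step gives the first reading of that change on its own, and it is large, as is the change on the ring oxygen, a 16-fold lower number from compound 1 to compound 2 (1.20 log units; beyond the scatter). Nothing at hand bears on why the cyano has this effect.

On these data alone, whether other groups at this position, such as a carboxylic acid, a primary amide or a longer chain, would match the cyano stays open. Also open, as far as these compounds go, is how the cyano step and the ring oxygen step combine on a single core.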